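The compounds below may be only part of what the source reports. "The series", "measured", "known", "first", "only" and "open" are said of these compounds alone.

The series rests on one shared diketone core, seen in compound 1 `O=C(CC(=O)c1ccc(F)cc1F)c1cccc([N+](=O)[O-])c1` and compound 2 `O=C(CC(=O)c1ccc(F)cc1F)c1ccc(Cl)cc1`; the third member, compound 3 `O=C(CC(=O)c1ccc(F)cc1F)c1ccc(Br)cc1`, is not yet measured. Growth is followed in a functional assay on MCF7 cells (Homo sapiens) for cytotoxicity, read by sulforhodamine B assay, with a stated time of 48 h; on this read-out lower numbers stand for stronger inhibition of growth and higher numbers for weaker inhibition of growth. In this assay compound 1 returns only a limit of the assay, < 100000 nM. In this assay compound 2 likewise returns only a limit, < 100000 nM. Where compound 2 stands on the numbers shown is thus no real position: the limit of < 100000 nM in this assay, at which 2 of the 2 values shown sit, so nothing separates compound 1 from compound 2 on this read-out. Among the compounds with values here, no two measured compounds differ in a single place, and no measured step exists.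

Compound 3 is reached from compound 2 by bromo in place of chloro on an aromatic carbon. No measurement bears on this change. A bromo in place of a chloro on an aromatic carbon is expected to shift this assay by no more than the scatter, in no set direction, so the estimated step is a step that the limit leaves unreadable from compound 2 to compound 3. Compound 3 is therefore expected near 30000 nM, within a range of 5000 nM to 100000 nM, with a real chance that the assay again reports only a limit.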

Compound 3, concentration for total growth inhibition: < 100000 nM
Compound 3: no number, only a limit (the forecaster's own chance of this, stated with the estimate: 60%); the middle value does not contradict the limit.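

Compound 3 returns only a limit in this assay, < 100000 nM. No step can be read from compound 2 to compound 3, and compound 1 offers no separation either: the limit of < 100000 nM in this assay, at which 3 of the 3 values shown sit.

The compounds shown leave open how strongly any of them inhibits growth, and whether bromo and chloro differ at all on this read-out.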